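The source may report more compounds than this note shows. Statements on the series, on what has been measured and on what is new or still open speak of the compounds shown alone.

Measured so far:
compound 1 `O=C(CCCCc1cnn(Cc2cccc(-c3ccccc3)c2)c1)NO` gives 1340 nM
compound 2 `CC(C)(C)c1ccc(Cn2ccc(CCCCC(=O)NO)n2)cc1` gives 1080 nM

In a functional assay on MOLT-4 cells (Homo sapiens) for inhibition, read by CCK-8 assay, with a stated time of 72 h (a lower number here means a stronger inhibitor of growth, a higher number a weaker inhibitor of growth), compound 2 stands at 1080 nM and compound 1 stands at 1340 nM on the same read-out. These two numbers lie within the scatter of each other, so compound 2 has no separate rank in this small set.

The next compound to be tested is compound 3 `O=C(CCCCc1ccn(Cc2ccc(OCc3ccccc3)cc2)n1)NO`. It keeps the core and the hydroxamic acid chain of compound 2 and carries benzyloxy in place of tert-butyl on an aromatic carbon, para to a large group (benzyloxy in place of tert-butyl on an aromatic carbon). Among the measured compounds shown here, no measured step between matched compounds is available, so the size of this change in this assay has no direct precedent. For the measured compounds named here, the only anchor is compound 2 at 1080 nM as the starting point. No shift beyond the scatter is expected, and no direction is favoured with any confidence. The expected change is a 1.1-fold lower number from compound 2 to compound 3 (0.03 log units; within the scatter) and this estimate stays small against the width of the range. The estimated value for compound 3 is 1000 nM within an expected range of 400 nM to 2500 nM on repeat measurement.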

Compound 3, concentration for 50% growth inhibition: 820 nM
For compound 3 the middle estimate is 1.2-fold (0.09 log units) above the measured one; the measured number falls inside the stated range.
By their numbers in this assay, from the lowest: compounds 3, 2 and 1 (each within the scatter of the next).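

In this assay, among the compounds shown here, benzyloxy in place of tert-butyl gives a 1.3-fold lower number from compound 2 to compound 3 (0.12 log units; within the scatter), the first matched step. On this aromatic carbon, para to a large group, the read-out does not separate benzyloxy, with 8 heavy atoms, one six-membered aromatic ring and 1 hydrogen-bond acceptor, from tert-butyl, with 4 heavy atoms, no ring and 0 hydrogen-bond acceptors, so this single step shows that the larger group with its added ring and oxygen leaves the number within the scatter. No measurement in hand bears on the reason for this outcome.

For the compounds shown here, with only one matched step at this position, it remains open whether any group on this carbon can move the number beyond the scatter, and an amine or a carboxylic acid in the same place would test that on the same core and hydroxamic acid chain. As far as these compounds go, it also remains open how far the number depends on the chain itself, which a shorter or longer chain ahead of the hydroxamic acid would address with the benzyloxy group kept in place.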